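The compounds below may be only part of what the source reports. "The series", "measured", "known", "first", "only" and "open" are said of these compounds alone.

Compound 1 `COc1ccc(C(C)N(Cc2ccc(C(C)(C)C)cc2)Cc2cc3cc(C)ccc3[nH]c2=O)cc1Cl` in a toxicity assay on MDCK cells (Canis lupus familiaris) for cytotoxicity, read by crystal violet staining, with a stated time of 48 h (a lower number here means that less compound is tolerated, a higher number that more compound is tolerated), gives > 10000 nM, which is a limit of the assay.
Compound 2 `COc1ccc2[nH]c(=O)c(CN(Cc3ccc(C(C)(C)C)cc3)C(C)c3ccc(OC)c(Cl)c3)cc2c1` in this assay gives > 10000 nM, again a limit of the assay.

Within the data shown here, compound 2 therefore stands at the limit of this assay and not at a number; the only other value shown, that of compound 1, sits at the same limit, as the limit of > 10000 nM in this assay, at which 2 of the 2 values shown sit, records. Among the measured compounds shown here, the single measured step, a step that the two limits leave unreadable from compound 1 to compound 2, cannot be read in size, since both of its ends are limits.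

Compound 3 `COc1ccc(C(C)N(Cc2ccc(C(C)(C)C)cc2)Cc2cc3cc(C4CC4)ccc3[nH]c2=O)cc1Cl` differs from compound 2 by cyclopropyl in place of methoxy on an aromatic carbon. No measured step bears directly on this change: the one step shown touches the same place on the shared core but remains unreadable, and no step exchanges a methoxy for a cyclopropyl. With both values shown resting at the limit, the expectation for compound 3 in this assay is a further value at or beyond that limit, that is, no step beyond the scatter, a step that the limit leaves unreadable from compound 2 to compound 3. Compound 3 is thus estimated at 15000 nM, with a range from 7000 nM to 50000 nM, and most likely reported once more as a limit.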

Compound 3, half-maximal cytotoxic concentration: > 10000 nM
Compound 3 gave a limit, no number; the forecaster's own chance of this, stated with the estimate: 80%; the middle value is on the limit's open side.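

Among these compounds, compound 3, like compound 1 and compound 2, rests at a limit and not at a number, so no step from either of them to compound 3 can be read: the limit of > 10000 nM in this assay, at which 3 of the 3 values shown sit. The compounds shown leave open what concentration of any of the three marks the onset of cytotoxicity in this assay, and whether methyl, methoxy and cyclopropyl on that aromatic carbon differ there at all.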